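Adding Fluorine to the Phenyl Ring of Compound 2

The compounds below may be only part of what the source reports. "The series", "measured", "known", "first", "only" and "open" are said of these compounds alone.

Compound 1 `O=C(/C(=C/c1ccccc1)CCl)c1ccccc1` and compound 2 `CC(=O)OC/C(=C\c1ccccc1)C(=O)c1ccccc1` share one core and differ only in a chain substituent. In a functional assay on WiDr cells (Homo sapiens) for inhibition, read by sulforhodamine B assay, with a stated time of 48 h (on this read-out lower numbers stand for stronger inhibition of growth and higher numbers for weaker inhibition of growth), compound 1 gives 18000 nM and compound 2 gives 17000 nM; the step of a 1.1-fold lower number from compound 1 to compound 2 (0.02 log units; within the scatter) lies within the scatter, so the two values sit side by side with no real gap. Compound 3 `CC(=O)OC/C(=C\c1ccccc1F)C(=O)c1ccccc1` differs from compound 2 by fluoro in place of hydrogen on an aromatic carbon, a change on the ring rather than the chain. For the measured compounds named here, no measured step touches that ring, so nothing here speaks for or against a shift; the default expectation is a step of no change at the digits printed from compound 2 to compound 3 (within the scatter), not beyond the scatter. Compound 3 is therefore estimated at 17000 nM, between 8000 nM and 36000 nM.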

Compound 3, concentration for 50% growth inhibition: 19000 nM
Beside the measured number, compound 3's estimate is 1.1-fold (0.05 log units) below it; the measured number falls inside the stated range.
By their numbers in this assay, from the lowest: compounds 2, 1 and 3 (each within the scatter of the next).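

The ring now has a measured step of its own: in this assay fluoro in place of hydrogen, on an aromatic carbon ortho to a large group, gives a 1.1-fold higher number from compound 2 to compound 3 (0.05 log units; within the scatter) and so the two numbers cannot be told apart. A single fluorine at this position therefore shows no real effect on this read-out. No outside evidence bears on this result. On these data alone, whether an amine or a methoxy group at this position would shift the number stays open. So does the effect of fluoro elsewhere on the ring.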